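Swapping the aryl group on a limit compound

The source may hold more compounds than are shown below. What is called first, only, known or untested is meant among the compounds shown, and "the series" means these compounds.

In a functional assay on A549 cells (Homo sapiens) for antiproliferative activity, read by MTT assay, with a stated time of 72 h (on this read-out lower numbers stand for stronger inhibition and higher numbers for weaker inhibition), compound 3 `Nc1ccccc1NC(=O)CCCCCCc1nc(-c2ccc(C(F)(F)F)cc2)no1` is known only as a limit, > 100000 nM.

Compound 2 `Cc1ccc(-c2noc(CCCCCCC(=O)Nc3ccccc3N)n2)cc1` gives 9170 nM. Compound 1 `O=C(CCCCCCc1nc(-c2ccccc2Cl)no1)NO`, which has a different chain end but already carries the 2-chlorophenyl group, gives 8870 nM.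

Compound 4 `Nc1ccccc1NC(=O)CCCCCCc1nc(-c2ccccc2Cl)no1` differs from compound 3 by 2-chlorophenyl in place of 4-(trifluoromethyl)phenyl on an aromatic carbon: 2-chlorophenyl in place of 4-(trifluoromethyl)phenyl.

Within the data shown here, the one measured step at this place, an at least 10-fold higher number from compound 2 to compound 3 (1.03 log units; beyond the scatter), is large, so the aryl group can move this read-out strongly. A large step towards lower numbers is therefore expected, estimated as an at least 6.6-fold lower number from compound 3 to compound 4 (0.82 log units; beyond the scatter).

For compound 4 the estimate is 15000 nM, with an expected range of 4000 nM to 60000 nM.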

Compound 4, half-maximal inhibitory concentration: > 100000 nM
Compound 4: no number, only a limit; the forecaster's own chance of this, stated with the estimate: 20%; middle value at least 6.6-fold (0.82 log units) away from the limit.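

Compound 3 and compound 4 both stand only as limits, and the step between them cannot be read: the limit of > 100000 nM in this assay, at which 2 of the 4 values shown sit. With the 2-aminophenyl amide end, 2-chlorophenyl does not hold the level of 4-methylphenyl (an at least 10-fold higher number from compound 2 to compound 4 (1.03 log units; beyond the scatter)). The chain end matters as well, since 2-chlorophenyl gives a readable number only with the hydroxy end among the compounds shown (an at least 11-fold higher number from compound 1 to compound 4 (1.05 log units; beyond the scatter)).

Still open, from the compounds shown here alone, is whether a plain phenyl or a 4-chlorophenyl on the 2-aminophenyl amide gives a readable number. Also open, going by these compounds, is whether a longer chain moves it.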